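Ring-aryl substitution in a thiol neprilysin inhibitor series

The source may report more compounds than this note shows. Statements on the series, on what has been measured and on what is new or still open speak of the compounds shown alone.

Three compounds share one core and differ in the aryl group on the saturated ring carbon and on the thiol side chain. Compound 1 `O=C(NCC(=O)N1[C@@H](c2ccccc2)CC[C@H]1C(=O)O)[C@@H](S)Cc1ccc(O)cc1` gives 3.4 nM in an assay on isolated protein for inhibition of Neprilysin (Oryctolagus cuniculus); on this read-out higher numbers stand for weaker inhibition and lower numbers for stronger inhibition. Compound 2 `O=C(NCC(=O)N1[C@@H](c2ccccc2O)CC[C@H]1C(=O)O)[C@@H](S)Cc1ccccc1` gives 1 nM in this assay. Compound 3 `Cc1ccc([C@H]2CC[C@@H](C(=O)O)N2C(=O)CNC(=O)[C@@H](S)Cc2ccc(O)cc2)cc1` gives 5.5 nM in this assay, the highest number of the three; the gap to compound 1 is within the scatter, the gap to compound 2 is beyond it. Among the compounds with values here, the only single-point step so far, a 1.6-fold higher number from compound 1 to compound 3 (0.21 log units; within the scatter), shows that a methyl on the ring aryl changes little.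

Compound 4 `O=C(NCC(=O)N1[C@@H](c2ccccc2O)CC[C@H]1C(=O)O)[C@@H](S)Cc1ccc(O)cc1` carries 2-hydroxyphenyl in place of 4-methylphenyl on a saturated ring carbon. Within the data shown here, no measured step covers this exact change. Compound 2, which also carries a 2-hydroxyphenyl on the ring but a phenyl on the thiol side, gives 1 nM, the lowest number seen, while the two compounds with a 4-hydroxyphenyl on the thiol side both sit higher. The step of a 2.8-fold lower number from compound 3 to compound 4 (0.44 log units; beyond the scatter) is therefore expected to be a modest decrease in the number. Compound 4 is estimated at 2 nM, with a range from 0.6 nM to 7 nM.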

Compound 4, half-maximal inhibitory concentration: 3.5 nM
Beside the measured number, compound 4's estimate is 1.8-fold (0.24 log units) below it; low and high end bracket the measured number.
By their numbers in this assay, from the lowest: compound 2; then compounds 1, 4 and 3 (each within the scatter of the next).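

With the 4-hydroxyphenyl on the thiol side, the aryl on the saturated ring carbon has so far made no difference beyond the scatter: 2-hydroxyphenyl in place of 4-methylphenyl gives a 1.6-fold lower number from compound 3 to compound 4 (0.20 log units; within the scatter) and hydroxy on the ring phenyl gives a 1.0-fold higher number from compound 1 to compound 4 (0.01 log units; within the scatter) in this assay. The thiol side is where a step beyond the scatter now appears: with 2-hydroxyphenyl fixed on the ring, hydroxy on the thiol-side phenyl gives a 3.5-fold higher number from compound 2 to compound 4 (0.54 log units; beyond the scatter), so the low number of compound 2 does not carry over to every compound with that ring aryl. No measurement bears on the cause of these steps.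

The thiol-side step is shown only with 2-hydroxyphenyl on the ring, so its size with a ring phenyl or 4-methylphenyl remains open. Also open, from the compounds shown here alone, is how an amine or a carboxylic acid on the ring aryl would read.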